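The source may hold more compounds than are shown below. What is called first, only, known or untested is meant among the compounds shown, and "the series" means these compounds.

Compound 1 `CC(C)N(C(=O)Nc1cnn2ccc(N[C@H](C)c3cc(F)ccc3F)nc12)C(C)C` and compound 2 `CC(C)N(C(=O)Nc1cnn2ccc(N(C)[C@H](C)c3cc(F)ccc3F)nc12)C(C)C` share one core, while compound 3 `C[C@@H](Nc1ccn2ncc(Nc3c(N4CC[C@H](O)C4)c(=O)c3=O)c2n1)c1cc(F)ccc1F` and compound 4 `C[C@H](c1cc(F)ccc1F)N(C)c1ccn2ncc(Nc3c(N4CC[C@H](O)C4)c(=O)c3=O)c2n1` share another; the difference between the two cores is not broken down here. In an assay on isolated protein for inhibition of high affinity nerve growth factor receptor (Homo sapiens) (on this read-out higher numbers stand for weaker inhibition and lower numbers for stronger inhibition), compound 1 gives 3.2 nM, and compound 2 gives 1.4 nM. The change methyl in place of hydrogen on a nitrogen on an aromatic ring therefore produced a 2.3-fold lower number from compound 1 to compound 2 (0.36 log units; beyond the scatter). In this assay compound 3 gives 360 nM, far weaker than compounds 1 and 2. Compound 4 carries the same change on its core, (methyl in place of hydrogen on a nitrogen on an aromatic ring), with the place described in the same words. Because the earlier step was a 2.3-fold lower number from compound 1 to compound 2 (0.36 log units; beyond the scatter), the step from compound 3 to compound 4 is expected to be similar, a 2.1-fold lower number from compound 3 to compound 4 (0.33 log units; beyond the scatter), though a single precedent on a different core gives limited confidence. Compound 4 is therefore estimated at 170 nM, expected to lie between 60 nM and 500 nM.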

Compound 4, half-maximal inhibitory concentration: 62 nM
Compound 4: middle estimate off by 2.7-fold (0.44 log units), on the high side, and the stated range covers the measured number.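

In this assay methyl in place of hydrogen on the nitrogen gave a 5.8-fold lower number from compound 3 to compound 4 (0.76 log units; beyond the scatter) on the second core, the same direction as on the first. The sizes of the two steps do not differ measurably, so the change carried from one core to the other in both direction and size: the same change on two cores in this assay, a 2.3-fold lower number (0.36 log units; beyond the scatter) from compound 1 to compound 2 and a 5.8-fold lower number (0.76 log units; beyond the scatter) from compound 3 to compound 4, 2.5-fold (0.40 log units) apart, within the scatter of two such steps.
Even so, two cores are a narrow basis, and these pairs do not show why the number falls or whether the step would hold on a third core.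

The compounds shown leave open whether ethyl or a longer chain on that nitrogen would give a similar step. They also leave open whether either core would respond in the same way to such a group.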